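A few compounds are considered here, and "the series" means these few. Any claim that something is new, unique, unknown or untested is made for them only; others in the source may bear on it.

Measured in a functional assay on SW480 cells (Homo sapiens) for antiproliferative activity, read by MTT assay, with a stated time of 48 h; on this read-out lower numbers stand for stronger inhibition and higher numbers for weaker inhibition:
- compound 1 `CC(C)=CCC[C@]1(C)/C=C/[C@@H](OC(=O)C=C(C)C)[C@](C)(O)/C=C/C(=O)/C(CN(C(C)C)C(C)C)=C\C1`: 750 nM
- compound 2 `CC(C)=CCC[C@]1(C)/C=C/[C@@H](OC(=O)C=C(C)C)[C@](C)(O)/C=C/C(=O)/C(CN2CCCC2)=C\C1`: 310 nM
- compound 3 `CSC(=S)OC/C1=C/C[C@](C)(CCC=C(C)C)/C=C/[C@@H](OC(=O)C=C(C)C)[C@](C)(O)/C=C/C1=O`: 390 nM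

Compound 3 sits within the scatter of both other compounds. The steps reaching it, a 1.9-fold lower number from compound 1 to compound 3 (0.28 log units; within the scatter) and a 1.3-fold higher number from compound 2 to compound 3 (0.10 log units; within the scatter), are small. Only a 2.4-fold lower number from compound 1 to compound 2 (0.38 log units; beyond the scatter) exceeds the scatter, and modestly.

Compound 4 `CCN(CC)C(=O)/C1=C/C[C@](C)(CCC=C(C)C)/C=C/[C@@H](OC(=O)C=C(C)C)[C@](C)(O)/C=C/C1=O` carries the change a group of 7 heavy atoms (5 carbon, 1 nitrogen, 1 oxygen; no ring) in place of a group of 6 heavy atoms (3 carbon, 1 oxygen, 2 sulfur; no ring), on a double-bonded ring carbon: diethylcarbamoyl in place of a group of 6 heavy atoms, on a double-bonded ring carbon. The measured steps exchanged groups on a saturated chain carbon bound to a double-bonded ring carbon, and none introduced diethylcarbamoyl, so they bear on this change only loosely. Given the modest size of a 2.4-fold lower number from compound 1 to compound 2 (0.38 log units; beyond the scatter), no shift beyond the scatter is expected in this assay. The expected step is a 1.3-fold higher number from compound 3 to compound 4 (0.11 log units; within the scatter). Compound 4 is estimated at 500 nM, with an expected range of 170 nM to 1500 nM.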

Compound 4, half-maximal inhibitory concentration: 11700 nM
The estimate for compound 4 lay 23-fold (1.37 log units) below the measured number, and the stated range ends below it.
By their numbers in this assay, from the lowest: compounds 2, 3 and 1 (each within the scatter of the next, the first and the last beyond it); then compound 4.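

On the double-bonded ring carbon, diethylcarbamoyl gives a large rise in the number in this assay: a 30-fold higher number from compound 3 to compound 4 (1.48 log units; beyond the scatter), a 38-fold higher number from compound 2 to compound 4 (1.58 log units; beyond the scatter) and a 16-fold higher number from compound 1 to compound 4 (1.19 log units; beyond the scatter). This position is therefore not indifferent to every exchange, and compound 4 alone lacks the saturated chain carbon bound to that ring carbon. No data available here explain the shift.

Compound 4 cannot separate the carbonyl from its diethylamino part. On these data alone, a diethylaminomethyl group or a carboxylic acid at this position could separate them, and how either would read remains open.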